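Replacing furan-2-yl with iodo on compound 1

The source may hold more compounds than are shown below. What is called first, only, known or untested is meant among the compounds shown, and "the series" means these compounds.

In a functional assay on CEM-DNR-bulk cells (Homo sapiens), read by MTT assay, with a stated time of 72 h (a lower number here means a stronger inhibitor, a higher number a weaker inhibitor), compound 1 `CNc1ncnc2c1c(-c1ccco1)cn2[C@@H]1O[C@H](CO)[C@@H](O)[C@H]1O` gives > 20000 nM as its reading, which is a limit of the assay and not a number. A close relative, compound 2 `O=c1[nH]cnc2c1c(-c1cc3ccccc3o1)cn2[C@@H]1O[C@H](CO)[C@@H](O)[C@H]1O`, gives > 20000 nM as its reading, again a limit and not a number. Going by the values given here, no true potency has therefore been measured yet, and no step between measured compounds is available as a guide. Compound 3 `CNc1ncnc2c1c(I)cn2[C@@H]1O[C@H](CO)[C@@H](O)[C@H]1O` differs from compound 1 in one place (iodo in place of furan-2-yl on an aromatic carbon), with iodo in place of furan-2-yl on an aromatic carbon. The expected change in this assay is an at least 2.0-fold lower number from compound 1 to compound 3 (0.30 log units; that floor lies within the scatter) as a modest move towards a stronger inhibitor, and this is an uncertain expectation, since another limit reading remains quite possible. In this assay the estimate for compound 3 is 10000 nM with an expected range from 1500 nM to 20000 nM for its measured value.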

Compound 3, half-maximal inhibitory concentration: > 20000 nM
Compound 3 ended at the assay's limit; the forecaster's own chance of this, stated with the estimate: 45%; at least 2.0-fold (0.30 log units) between middle value and limit.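

In this assay compound 3 gives > 20000 nM, a limit and not a number. Going by these compounds alone, compound 1 also reads at a limit, so no step from compound 1 to compound 3 can be read. The true potency of every compound shown stays open, because all share one reading: the limit of > 20000 nM in this assay, at which 3 of the 3 values shown sit.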